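Ethoxy in Place of Fluoro: an Expected Antiproliferative Value

The source may hold more compounds than are shown below. What is called first, only, known or untested is meant among the compounds shown, and "the series" means these compounds.

Compound 1 `COc1cc(-n2cnc3ccc(-c4ccc(Cl)cc4Cl)cc32)cc(OC)c1OC`, in a functional assay on A549 cells (Homo sapiens) for antiproliferative activity, read by MTT assay, with a stated time of 72 h (on this read-out higher numbers stand for weaker inhibition and lower numbers for stronger inhibition), gives > 10000 nM, which is a limit of the assay and not a number.
Compound 2 `COc1cc(-n2cnc3ccc(-c4ccc(O)cc4)cc32)cc(OC)c1OC` gives 5090 nM.
Compound 3 `COc1cc(-n2cnc3ccc(-c4ccc(F)cc4)cc32)cc(OC)c1OC` gives 6740 nM.

Compound 3 stands highest of the two numbers measured, yet its nearest neighbour, compound 2, sits only a 1.3-fold higher number from compound 2 to compound 3 (0.12 log units; within the scatter) away, so the two cannot be ordered. Compound 1 reaches only the limit (the limit of > 10000 nM in this assay, at which 1 of the 3 values shown sits), and the steps of an at least 1.9-fold lower number from compound 1 to compound 2 (0.29 log units; that floor lies within the scatter) and an at least 1.4-fold lower number from compound 1 to compound 3 (0.17 log units; that floor lies within the scatter) are therefore floors, both within the scatter.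

Compound 4 `CCOc1ccc(-c2ccc3ncn(-c4cc(OC)c(OC)c(OC)c4)c3c2)cc1` differs from compound 3 by ethoxy in place of fluoro on an aromatic carbon. For the measured compounds named here, no measured step swaps fluoro for ethoxy. Going by the values given here, the only step that changes the group on the same ring carbon is a 1.3-fold higher number from compound 2 to compound 3 (0.12 log units; within the scatter), and it stayed within the scatter. The two floors from compound 1 add no direction either. The available evidence thus points to no step beyond the scatter in this assay, though a change as large as the ethoxy group leaves room for surprise in either direction.

Compound 4 is therefore estimated at 6000 nM, between 2000 nM and 18000 nM, which means an expected step of a 1.1-fold lower number from compound 3 to compound 4 (0.05 log units; within the scatter).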

Compound 4, half-maximal inhibitory concentration: 8550 nM
Beside the measured number, compound 4's estimate is 1.4-fold (0.15 log units) below it; the measured number falls inside the stated range.
By their numbers in this assay, from the lowest: compounds 2, 3 and 4 (each within the scatter of the next). At a limit, above all of these: compound 1.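

For the compounds shown here, at this carbon, para to a large group, the earlier compounds offered only hydroxy and fluoro, and the larger ethoxy group, with its 3 heavy atoms, now adds a third substituent without separating itself from either in this assay: the exchange for fluoro gives a 1.3-fold higher number from compound 3 to compound 4 (0.10 log units; within the scatter), and putting ethyl on the oxygen of the hydroxy group gives a 1.7-fold higher number from compound 2 to compound 4 (0.23 log units; within the scatter). The position therefore accepts hydroxy, fluoro and ethoxy with no readable difference among them, so these three compounds cannot be ordered and the added size of ethoxy has no measurable consequence here. The comparison with the 2,4-dichlorophenyl compound adds no direction, since the step (an at least 1.1-fold lower number from compound 1 to compound 4 (0.06 log units; that floor lies within the scatter)) is only a floor, and compound 1 stands at a limit and not a number: the limit of > 10000 nM in this assay, at which 1 of the 4 values shown sits.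

The compounds shown leave open whether any group on this carbon can move the number beyond the scatter, for instance an amine, a carboxylic acid or a chain longer than ethoxy. They also leave open whether a single chloro at this carbon would read differently from the 4-fluorophenyl compound.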